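The compounds below may be only part of what the source reports. "The series", "measured", "known", "first", "only" and "open" are said of these compounds alone.

Compound 3 `CCOC(=O)CN1CC[C@H](n2c(Nc3ccc(F)cc3)nc3cnc(Nc4ccc(N5CCN(C)CC5)cc4)nc32)C1` stands apart from its two companions. In a functional assay on HCC827 cells (Homo sapiens) for antiproliferative activity, read by MTT assay, with a stated time of 72 h (a lower number here means a stronger inhibitor, a higher number a weaker inhibitor), compound 3 gives 1810 nM, the highest of the three numbers. Compound 1 `CN1CCN(c2ccc(Nc3ncc4nc(Nc5ccc(F)cc5)n(CCNS(=O)(=O)C5CC5)c4n3)cc2)CC1` gives 50 nM in this assay, and compound 2 `CN1CCN(c2ccc(Nc3ncc4nc(Nc5ccc(F)cc5)n([C@@H]5CCN(C(=O)OC(C)(C)C)C5)c4n3)cc2)CC1` gives 27 nM; the step of a 1.9-fold lower number from compound 1 to compound 2 (0.27 log units; within the scatter) is small, so these two cannot be ranked against each other. Against them compound 3 is clearly weaker: a 36-fold higher number from compound 1 to compound 3 (1.56 log units; beyond the scatter) and a 67-fold higher number from compound 2 to compound 3 (1.83 log units; beyond the scatter).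

Compound 4 `CN1CCN(c2ccc(Nc3ncc4nc(Nc5ccc(F)cc5)n([C@H]5CCCN(C(=O)CO)C5)c4n3)cc2)CC1` differs from compound 3 in one place: 1-((hydroxymethyl)carbonyl)piperidin-3-yl in place of 1-((ethoxycarbonyl)methyl)pyrrolidin-3-yl on an aromatic nitrogen. The step that bears most directly on this change is the one from compound 2 to compound 3, where a group carrying a carbonyl on the ring nitrogen was exchanged for the ethoxycarbonylmethyl group and the number rose sharply, as shown by a 67-fold higher number from compound 2 to compound 3 (1.83 log units; beyond the scatter). Going by the values given here, compound 4 again carries a carbonyl on the ring nitrogen, so the expectation is that the large loss seen in compound 3 is undone and the number falls back toward the range of compound 1 and compound 2, though the change of ring size has no precedent among the measured compounds.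

Compound 4 is therefore expected to give 70 nM in this assay, within a range of 20 nM to 400 nM, an expected step of a 26-fold lower number from compound 3 to compound 4 (1.41 log units; beyond the scatter).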

Compound 4, half-maximal inhibitory concentration: 1.8 nM
Beside the measured number, compound 4's estimate is 39-fold (1.59 log units) above it, outside the stated range (below it).
By their numbers in this assay, from the lowest: compound 4; then compounds 2 and 1 (each within the scatter of the next); then compound 3.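

In this assay, going by these compounds alone, the group on this aromatic nitrogen can do more than avoid a loss: 1-((hydroxymethyl)carbonyl)piperidin-3-yl gives a 1000-fold lower number from compound 3 to compound 4 (3.00 log units; beyond the scatter), a swing far larger than any seen among the earlier compounds. It also goes well past the two better earlier compounds, which could not be ranked against each other, with a 15-fold lower number from compound 2 to compound 4 (1.18 log units; beyond the scatter) and a 28-fold lower number from compound 1 to compound 4 (1.44 log units; beyond the scatter), making compound 4 the strongest of the four and showing that this position can gain activity as well as lose it. No measurement is available here that explains this gain.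

The step from compound 3 changes the ring from five-membered to six-membered and replaces the group on the ring nitrogen at the same time, and the compounds shown do not separate these two changes. A 1-acetylpiperidin-3-yl group, which lacks the hydroxyl, and a pyrrolidin-3-yl ring carrying the same (hydroxymethyl)carbonyl group would show whether the hydroxyl, the larger ring or both stand behind the gain.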